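A few compounds are considered here, and "the series" means these few. Any claim that something is new, unique, unknown or untested is made for them only; others in the source may bear on it.

Measured in a functional assay on HepG2 cells (Homo sapiens) for cytotoxicity, read by MTT assay, with a stated time of 48 h; a higher number here means a weaker inhibitor, a lower number a stronger inhibitor:
- Compound 1 `CC1=NN(C(=O)CCc2ccccc2)C(c2cc(Br)ccc2O)C1`: 17900 nM
- Compound 2 `CC1=NN(S(=O)(=O)c2ccc(C)cc2)C(c2cc(Br)ccc2O)C1`: 20800 nM

Compound 2 and compound 1 sit within the usual scatter of each other, so neither can be ranked ahead of the other on these numbers. Compound 3 `CC1=NN(S(=O)(=O)c2ccc(C)cc2)C(c2cc(Br)cc(Br)c2O)C1` is compound 2 with bromo in place of hydrogen on an aromatic carbon, ortho to a hydroxy group. For the measured compounds named here, no measured pair shows what such an added bromo does in this assay, so this expectation is a cautious one. It starts from compound 2 at 20800 nM and anticipates a modest move toward a lower number, possibly no larger than the scatter. The expected change is a 1.5-fold lower number from compound 2 to compound 3 (0.17 log units; within the scatter). For compound 3 the estimated value is 14000 nM, with an expected range from 6000 nM to 32000 nM.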

Compound 3, half-maximal inhibitory concentration: "not active" (no number reported)
For compound 3 the study gives words and no number; the estimate stays without a comparison.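

In this assay, for the compounds shown here, compound 3 is reported only in words as not active, without a number, so no step from compound 2 can be read. Nothing shown here explains this result. From the compounds shown here alone, how far the added bromo shifts the number in this assay stays open.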